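This account rests on a few compounds, and the source may have more. Where it says the series, first, only, none or still open, it means among the compounds named here.

Compound 1 `CC1(C)N(O)C(c2ccc(O)cc2)=[N+]([O-])C1(C)C` gives 40000 nM in a functional assay on PC-12 cells (Rattus norvegicus) for inhibition, read by MTT assay; on this read-out lower numbers stand for an effect already at smaller amounts and higher numbers for an effect only at larger amounts of compound.
Compound 2 `CC1(C)N(O)C(c2ccc(OCC(=O)N[C@@H](CCCCN)C(=O)O)cc2)=[N+]([O-])C1(C)C` gives 90600 nM in this assay.
Compound 3 `CC1(C)N(O)C(c2ccc(OCCNC(=O)C[C@H](N)C(=O)O)cc2)=[N+]([O-])C1(C)C` gives 42300 nM in this assay.

Among these three numbers compound 3 stands second highest. Its nearest neighbour is compound 1, whose number lies within the usual scatter of it, so the two cannot be told apart; compound 2 is furthest away, with a number beyond the scatter. All three tails on the phenol oxygen of the shared core thus leave the read-out close together.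

Compound 4 `CC1(C)N(O)C(c2ccc(OCCNC(=O)CC[C@H](N)C(=O)O)cc2)=[N+]([O-])C1(C)C` differs from compound 3 by 2-amino-2-carboxyethyl in place of amino(carboxy)methyl on a saturated chain carbon bound to a carbonyl carbon. Going by the values given here, no measured pair of this kind exists to lean on, and the three measured numbers spread little, so the step of a 1.1-fold higher number from compound 3 to compound 4 (0.03 log units; within the scatter) is expected to stay within the scatter, in no set direction. Compound 4 is therefore estimated at 45000 nM, with a range from 20000 nM to 100000 nM.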

Compound 4, half-maximal effective concentration: 41800 nM
For compound 4 the middle estimate is 1.1-fold (0.03 log units) above the measured one; the measured number falls inside the stated range.
By their numbers in this assay, from the lowest: compounds 1, 4 and 3 (each within the scatter of the next); then compound 2.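

Going by these compounds alone, this is the first measured pair that differs in one place: in this assay, 2-amino-2-carboxyethyl in place of amino(carboxy)methyl gives a 1.0-fold lower number from compound 3 to compound 4 (0.01 log units; within the scatter), so the two compounds cannot be told apart. At this position, the longer chain therefore leaves the read-out unchanged within the scatter. Nothing available here bears on why this is so.

Going by these compounds, whether a chain longer than 3-amino-3-carboxypropyl would also leave the number in place stays open. So does the effect of a tail ending in an amine alone or a carboxylic acid alone.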